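Trading a Large Side Group for a Cyclopropyl

A few compounds are considered here, and "the series" means these few. Any claim that something is new, unique, unknown or untested is made for them only; others in the source may bear on it.

Compound 1 `CC#C[C@@H](Cc1nnn[nH]1)c1ccc(OCc2ccc3scc(-c4cc(OCCOC)ccc4C)c3c2)cc1` is the starting point. In an ADME assay on microsomes from liver (Homo sapiens) for metabolic stability (on this read-out lower numbers stand for a shorter-lived compound and higher numbers for a longer-lived compound), compound 1 gives 0.867 h. Its only measured relative, compound 2 `CC#C[C@@H](Cc1nnn[nH]1)c1ccc(OCc2cc(F)c3scc(-c4ccc(OC)cc4C)c3c2)cc1`, gives 0.5 h in this assay. These two numbers lie within the usual scatter of repeated measurements, so they do not separate the two compounds.

Compound 3 `CC#C[C@@H](Cc1nnn[nH]1)c1ccc(OCc2ccc3scc(C4CC4)c3c2)cc1` keeps the core of compound 1 but carries cyclopropyl in place of 5-(2-methoxyethoxy)-2-methylphenyl on an aromatic carbon. That carbon belongs to a five-membered aromatic ring with 1 sulfur, two ring bonds from the ring sulfur. For the measured compounds named here, the entering group is much smaller than the one that leaves, yet no two measured compounds differ in one place, so the data offer no direct guide to this swap.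

Going by the values given here, the only anchors are compound 1 at 0.867 h and compound 2 at 0.5 h. In this assay, the expected outcome is therefore no step beyond the scatter, with a slight lean towards a longer-lived compound. The estimated step is a 1.4-fold higher number from compound 1 to compound 3 (0.14 log units; within the scatter). For compound 3 the expected value is 1.2 h, within an estimated range from 0.5 h to 3 h.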

Compound 3, half-life: 0.267 h
Estimate against measurement, compound 3: 4.5-fold (0.65 log units) above; measured number below the stated range.
By their numbers in this assay, from the lowest: compounds 3, 2 and 1 (each within the scatter of the next, the first and the last beyond it).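

In this assay, for the compounds shown here, replacing 5-(2-methoxyethoxy)-2-methylphenyl with cyclopropyl gives a 3.2-fold lower number from compound 1 to compound 3 (0.51 log units; beyond the scatter), the first direct reading of a change at this aromatic carbon, two ring bonds from the ring sulfur. This single pair shows that the group held at this carbon can shift the half-life by more than the usual scatter, and that going from 12 heavy atoms to 3 here brought a shorter-lived compound rather than a longer-lived one. Nothing available here accounts for the drop, so the reason for it remains unknown.

This one step changes several things at once: the six-membered aromatic ring, the methyl group, the 2-methoxyethoxy chain and the overall size all leave together, so their separate contributions cannot be told apart. From the compounds shown here alone, whether the half-life returns with a plain phenyl at this carbon, or with a small open group such as isopropyl, remains open, as does whether the same drop would appear on a core carrying other changes.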